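A few compounds are considered here, and "the series" means these few. Any claim that something is new, unique, unknown or untested is made for them only; others in the source may bear on it.

Measured so far:
compound 1, `O=C(Nc1cccc(-n2cc(-c3ccncc3)c(-c3ccc(Cl)c(O)c3)n2)c1)Nc1ccc(Cl)c(Cl)c1`, 29100 nM in a functional assay on NCI-H23 cells (Homo sapiens) for inhibition, read by sulforhodamine B assay, with a stated time of 48 h; on this read-out higher numbers stand for weaker inhibition of growth and lower numbers for stronger inhibition of growth;
compound 2, `O=C(Nc1cccc(-n2cc(-c3ccncc3)c(-c3ccc(Cl)c(O)c3)n2)c1)Nc1cc(C(F)(F)F)cc(C(F)(F)F)c1`, 3270 nM;
compound 3, `COc1cc(-c2nn(-c3cccc(NC(=O)Nc4cccc(C(F)(F)F)c4)c3)cc2-c2ccncc2)ccc1Cl`, 3410 nM.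

Compound 3 stands second highest of the three numbers. Its nearest neighbour is compound 2, whose value lies within the scatter of that of compound 3, so no order between the two can be read. Compound 1 stands furthest away, with a number beyond the scatter above that of compound 3.

Compound 4, `O=C(Nc1cccc(-n2cc(-c3ccncc3)c(-c3ccc(Cl)c(O)c3)n2)c1)Nc1cccc(C(F)(F)F)c1`, has not yet been measured. It differs from compound 3 in one place: hydrogen in place of methyl on an oxygen on an aromatic ring. Within the data shown here, no step between measured compounds that carries this same change is available, so the size of the step from compound 3 to compound 4 is open. The neighbours that carry the hydroxy, compound 2 with 3270 nM and compound 1 with 29100 nM, span a wide range, and compound 2 lies level with compound 3. Compound 4 is therefore expected to stay close to compound 3, with a step of a 1.0-fold higher number from compound 3 to compound 4 (0.01 log units; within the scatter) in this assay, and its estimated value is 3500 nM, between 1200 nM and 10000 nM.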

Compound 4, concentration for total growth inhibition: > 32500 nM
Compound 4: a limit, no number; the forecaster's own chance of this, stated with the estimate: 5%; at least 9.2-fold (0.96 log units) between middle value and limit.
By their numbers in this assay, from the lowest: compounds 2 and 3 (each within the scatter of the next); then compound 1. At a limit, above all of these: compound 4.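

In this assay, methoxy to hydroxy on the 4-chloro-3-methoxyphenyl group gives an at least 9.5-fold higher number from compound 3 to compound 4 (0.97 log units; beyond the scatter). Hydrogen in place of trifluoromethyl on an aromatic carbon gives an at least 9.9-fold higher number from compound 2 to compound 4 (0.99 log units; beyond the scatter), so that trifluoromethyl also counts in the hydroxy series, while an at least 1.1-fold higher number from compound 1 to compound 4 (0.04 log units; that floor lies within the scatter) cannot be read. Compound 4 stands as a limit and not a number, so both readable steps are floors: the limit of > 32500 nM in this assay, at which 1 of the 4 values shown sits.

On these data alone, whether methoxy to hydroxy carries a similar step alongside the 3,4-dichlorophenyl group stays open. As far as these compounds go, what an ethoxy group or an amine would give in place of the methoxy also stays open.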